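One Carbon Less on the Chain, on Two Cores

A few compounds are considered here, and "the series" means these few. Any claim that something is new, unique, unknown or untested is made for them only; others in the source may bear on it.

In a functional assay on HEK293 cells for agonist activity at G-protein coupled receptor 84 (Homo sapiens), read by calcium flux (a lower number here means a smaller maximal response, a higher number a larger maximal response), compound 1 `CCCCCCc1nc(O)cc(O)n1` gives 99.7%. Compound 2 `CCCCCc1nc(O)cc(O)n1` differs from it by hydrogen in place of methyl on a saturated chain carbon, five bonds along the chain from an aromatic carbon and gives 84.9% in this assay, a step of a number 14.8 percentage points lower from compound 1 to compound 2 (beyond the scatter). Compound 3 `CCCCCCCCc1cc(O)cc(O)n1` rests on a different core; the difference between the two cores is not broken down here. In this assay compound 3 gives 82.6%. Compound 4 `CCCCCCCc1cc(O)cc(O)n1` has not been measured; it differs from compound 3 by hydrogen in place of methyl on a saturated chain carbon, seven bonds along the chain from an aromatic carbon, the same kind of change as that between compound 1 and compound 2, though here the place is seven bonds along the chain from an aromatic carbon rather than five. Resting on the step of a number 14.8 percentage points lower from compound 1 to compound 2 (beyond the scatter), compound 4 is expected to show a step of a number 12.6 percentage points lower from compound 3 to compound 4 (beyond the scatter) in this assay. Compound 4 is therefore estimated at 70%, with a range from 52% to 88%.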

Compound 4, largest response reached (reported as percent of maximum), in percent of the reference or control that the assay uses: 87.8%
Estimate against measurement, compound 4: 17.8 percentage points below, within the range that was stated.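

Compared in this assay the same change on the second core gave a number 5.2 percentage points higher from compound 3 to compound 4 (within the scatter) and so the step seen on the first core did not carry over. Set side by side, the two steps differ: the same change on two cores in this assay, a number 14.8 percentage points lower (beyond the scatter) from compound 1 to compound 2 and a number 5.2 percentage points higher (within the scatter) from compound 3 to compound 4, 20 percentage points apart, beyond the scatter of two such steps. This shows that the size of the step cannot simply be transferred from one core to the other in this series, but with a single pair on each core it does not show whether the core itself or the place of the change, five bonds along the chain in one pair and seven in the other, sets the difference.

The compounds shown leave open how a longer chain would read on either core. They also leave open whether an amine or a carboxylic acid in place of that methyl would behave alike on both.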